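Thioether ring exchange on the anilide chain of compound 2

A few compounds are considered here, and "the series" means these few. Any claim that something is new, unique, unknown or untested is made for them only; others in the source may bear on it.

Measured so far, in a functional assay on MCF7 cells (Homo sapiens) for cytotoxicity, read by MTT assay, with a stated time of 24 h, tested at 0.64 ug/mL; on this read-out lower numbers stand for a weaker effect and higher numbers for a stronger effect at the one concentration tested:
compound 1 `Cn1c(-c2ccc(NC(=O)CCl)cc2)nc(-c2ccccc2)c1-c1ccccc1` gives 3.4%
compound 2 `Cn1nnnc1SCC(=O)Nc1ccc(-c2nc(-c3ccccc3)c(-c3ccccc3)n2C)cc1` gives 21.9%

For the measured compounds named here, compound 2 holds the higher of the two numbers; the only measured step is a number 18.5 percentage points higher from compound 1 to compound 2 (beyond the scatter), and that step is what separates compound 2 from compound 1.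

Compound 3 `Cn1c(-c2ccc(NC(=O)CSC3=NCCS3)cc2)nc(-c2ccccc2)c1-c1ccccc1` differs from compound 2 in one place: a group of 5 heavy atoms (3 carbon, 1 nitrogen, 1 sulfur; one five-membered non-aromatic ring with 2 hetero atoms) in place of a group of 6 heavy atoms (2 carbon, 4 nitrogen; one five-membered aromatic ring with 4 hetero atoms), on a sulfur. The sulfur and the saturated chain carbon bound to the carbonyl carbon are kept; only the ring hanging from the sulfur is exchanged.

Going by the values given here, the one measured step bears on this only loosely. It shows that putting a sulfanyl-linked ring in place of chloro raised the number in this assay by a modest amount, but it does not test one sulfanyl-linked ring against another. Among the compounds with values here, nothing among the measured compounds says whether the ring on the sulfur matters. The expectation for compound 3 is therefore a step of a number 3.9 percentage points lower from compound 2 to compound 3 (within the scatter), that is, no change beyond the scatter, with wide uncertainty. Compound 3 is estimated at 18%, in the range 5% to 32%.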

Compound 3, a percentage reported as activity, at one concentration (the size of the read-out at that concentration, not a potency): 10.3%
Beside the measured number, compound 3's estimate is 7.7 percentage points above it; the measured number falls inside the stated range.
By their numbers in this assay, from the lowest: compounds 1 and 3 (each within the scatter of the next); then compound 2.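

In this assay the ring hanging from the sulfur does matter, with a number 11.6 percentage points lower from compound 2 to compound 3 (beyond the scatter) when the five-membered non-aromatic ring with 2 hetero atoms replaces 1-methyl-1H-tetrazol-5-yl on the sulfur. A sulfanyl link alone therefore does not secure a rise over chloro in these compounds: the non-aromatic ring gives only a number 6.9 percentage points higher from compound 1 to compound 3 (within the scatter) and leaves no readable difference, while the step from chloro to the tetrazole stands beyond the scatter. No measurement at hand accounts for this difference between the two rings.

Open, going by these compounds, is whether the higher number belongs to the aromatic ring with 4 hetero atoms specifically or would also appear with another ring on the sulfur, such as a phenyl or a pyridine, and whether the sulfur itself could give way to an amine nitrogen at the same place. Also open, on these data alone, is how a longer chain between the sulfur and the carbonyl carbon, or a carboxylic acid in place of the ring, would read out, and since each number comes from a single concentration, none of them gives a potency.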